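Swapping the Dichlorophenyl for Nitrophenyl: Estimating Compound 4

The source may hold more compounds than are shown below. What is called first, only, known or untested is meant among the compounds shown, and "the series" means these compounds.

Measured so far in a functional assay on MCF7 cells (Homo sapiens) for inhibition, read by XTT assay, with a stated time of 48 h; on this read-out higher numbers stand for weaker inhibition and lower numbers for stronger inhibition:
Compound 1 `COc1ccc(C(=O)/C(=C/C2CCCCC2)CC(C)OC(C)=O)cc1` gives > 100000 nM, which is a limit of the assay rather than a number.
Compound 2 `C=C(C(=O)c1ccc(OC)cc1)C(OC(C)=O)c1ccc(Cl)cc1Cl` gives 8300 nM.
Compound 3 `C=C(C(=O)c1ccc(OC)cc1)C(OC(=O)c1ccccc1)c1ccc(Cl)cc1Cl` gives 26800 nM.

Among the measured compounds shown here, compound 3 therefore stands highest of the two numbers, meaning the weaker inhibition of the pair; the only measured step is a 3.2-fold higher number from compound 2 to compound 3 (0.51 log units; beyond the scatter), a modest worsening. Compound 1 sits at the limit of > 100000 nM in this assay, at which 1 of the 3 values shown sits, and gives no number to compare.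

Compound 4 `C=C(C(=O)c1ccc(OC)cc1)C(OC(=O)c1ccccc1)c1ccc([N+](=O)[O-])cc1` differs from compound 3 by 4-nitrophenyl in place of 2,4-dichlorophenyl on a saturated chain carbon bound to a double-bonded chain carbon and an oxygen next to a carbonyl group. For the measured compounds named here, no measured step touches this ring: the single step on record changes the group on the carbonyl carbon, a different place, so it offers no direct guide to the size or direction of this change. With nothing to lean on, the expectation for compound 4 in this assay is a number close to that of compound 3, with no step beyond the scatter, but with wide uncertainty. Compound 4 is thus estimated at 30000 nM, in the range 8000 nM to 120000 nM. The expected step is a 1.1-fold higher number from compound 3 to compound 4 (0.05 log units; within the scatter).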

Compound 4, half-maximal inhibitory concentration: 56100 nM
For compound 4 the middle estimate is 1.9-fold (0.27 log units) below the measured one; the range from low to high includes it.
By their numbers in this assay, from the lowest: compound 2; then compound 3; then compound 4. At a limit, above all of these: compound 1.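

In this assay this ring is not a silent position: 4-nitrophenyl in place of 2,4-dichlorophenyl gives a 2.1-fold higher number from compound 3 to compound 4 (0.32 log units; beyond the scatter), a modest move towards weaker inhibition. Among the compounds shown here, until now the only measured step lay on the carbonyl carbon, so this is the first sign that the ring on the saturated chain carbon also shifts the number. Nothing measured here says why this swap weakens inhibition.

As far as these compounds go, with a single ring swap, it stays open whether the shift follows from the nitro group arriving or from the two chlorines leaving, and what an amine or a carboxylic acid on this ring would do. From the compounds shown here alone, it is also open whether methyl in place of phenyl on the carbonyl carbon would lower the number with 4-nitrophenyl as it does with 2,4-dichlorophenyl.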